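A tolyl amide in place of the furan amide

The compounds below may be only part of what the source reports. "The series", "measured", "known", "first", "only" and "open" are said of these compounds alone.

Of the compounds shown here, two built on the same core have been measured. Compound 1 `Nc1ccc(C(=O)Nc2nc(-c3ccccc3)nc3c2nnn3Cc2ccccc2)cc1` gives 7.1 nM in an assay (strain Wistar) for displacement of a labelled ligand from adenosine receptor A1 (Rattus norvegicus), read by scintillation counting; a higher number here means a weaker inhibitor, a lower number a stronger inhibitor. Compound 2 `O=C(Nc1nc(-c2ccccc2)nc2c1nnn2Cc1ccccc1)c1ccoc1` gives 10 nM in this assay, the higher of the two numbers, though the step of a 1.4-fold higher number from compound 1 to compound 2 (0.15 log units; within the scatter) is too small to count as a real difference. Compound 3 `Cc1ccc(C(=O)Nc2nc(-c3ccccc3)nc3c2nnn3Cc2ccccc2)cc1` has not been measured yet; it differs from compound 2 by 4-methylphenyl in place of furan-3-yl on a carbonyl carbon. Among the compounds with values here, the only measured step at this position, a 1.4-fold higher number from compound 1 to compound 2 (0.15 log units; within the scatter), swapped one aryl group for another on the same carbonyl carbon without a change beyond the scatter, and it bears on the present step only loosely. With that single precedent, the step of a 1.3-fold lower number from compound 2 to compound 3 (0.10 log units; within the scatter) is expected to stay within the scatter as well. For compound 3 the estimate in this assay is therefore 8 nM, with a range from 3 nM to 25 nM.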

Compound 3, inhibition constant: 709 nM
Estimate against measurement, compound 3: 89-fold (1.95 log units) below; the whole stated range lies below it.
By their numbers in this assay, from the lowest: compounds 1 and 2 (each within the scatter of the next); then compound 3.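

This position on the carbonyl carbon is much less tolerant than the first two compounds suggested: in this assay, replacing furan-3-yl with 4-methylphenyl gives a 71-fold higher number from compound 2 to compound 3 (1.85 log units; beyond the scatter). Replacing amino with methyl on an aromatic carbon gives a 100-fold higher number from compound 1 to compound 3 (2.00 log units; beyond the scatter), so one group on the phenyl ring separates a strong inhibitor from a much weaker one, and having a phenyl ring there does not by itself set the number. No available evidence accounts for this drop.

These compounds cannot show whether the methyl itself weakens inhibition or whether the amino group is what supports it. A plain phenyl with neither group would help separate those two readings, while a hydroxyl or methoxy group in the same place would test how much depends on the amino group specifically.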